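A Phenyl Substituent Tried Against Three Limit Values

The compounds below may be only part of what the source reports. "The series", "measured", "known", "first", "only" and "open" are said of these compounds alone.

Three compounds have been run in an assay on HEK-293T cells for inhibition of phospholipase A and acyltransferase 3 (Homo sapiens), with stated times of 30 min and 20 min; on this read-out lower numbers stand for stronger inhibition and higher numbers for weaker inhibition. Compound 1 `O=C(CCc1ccc(Cl)cc1)C(=O)N1CCCCC1` carries a piperidin-1-yl on the carbonyl carbon, while compound 3 `O=C(CCc1ccc(Cl)cc1)C(=O)N1CCCC1` carries a pyrrolidin-1-yl there; the two cores differ by piperidin-1-yl in place of pyrrolidin-1-yl on a carbonyl carbon. Compound 2 `O=C(CCc1ccc(Cl)cc1)C(=O)N1CC[C@@H](c2ccccc2)C1` adds a phenyl to compound 3, a difference of phenyl in place of hydrogen on a saturated ring carbon. In this assay compound 1 gives only a limit, > 10000 nM. Compound 3 likewise gives a limit, > 10000 nM. Compound 2 also gives a limit, > 10000 nM. All three therefore sit at the limit of > 10000 nM in this assay, at which 3 of the 3 values shown sit, and the steps are a step that the two limits leave unreadable from compound 1 to compound 3 and a step that the two limits leave unreadable from compound 3 to compound 2.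

Compound 4 `O=C(CCc1ccc(Cl)cc1)C(=O)N1CCCC[C@H]1c1ccccc1` is not yet measured. It differs from compound 1 by phenyl in place of hydrogen on a saturated ring carbon. This is the same kind of change as from compound 3 to compound 2, not the same: in compound 4 the phenyl sits on a six-membered non-aromatic ring, next to the ring nitrogen and next to the ring atom that bears a large group, whereas in compound 2 it sits on a five-membered ring, two ring bonds from each. The expected step is a step that the limit leaves unreadable from compound 1 to compound 4, resting on the fact that the related change gave a step that the two limits leave unreadable from compound 3 to compound 2 with both values at the limit. Compound 4 is estimated at 15000 nM in this assay, most probably reported again only as a limit.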

Compound 4, half-maximal inhibitory concentration: > 10000 nM
Compound 4 gave a limit, no number; the forecaster's own chance of this, stated with the estimate: 80%; the middle value lies beyond the limit too.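

Compound 1 and compound 4 yield no readable step, because each of the two values is only a limit and not a number: the limit of > 10000 nM in this assay, at which 4 of the 4 values shown sit.

The compounds shown leave open how strongly any of the four inhibits, and whether a phenyl in place of hydrogen on a saturated ring carbon changes inhibition at all.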